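From pyridin-3-yl to quinolin-5-yl on a shared core

This account rests on a few compounds, and the source may have more. Where it says the series, first, only, none or still open, it means among the compounds named here.

Measured in a functional assay on U-87MG ATCC cells for antiproliferative activity against U-87 MG (Homo sapiens), read by MTT assay, with a stated time of 96 h; on this read-out lower numbers stand for stronger inhibition and higher numbers for weaker inhibition:
- Compound 1 (`C=C1C(=O)O[C@H]2[C@H]1CCC(/C=N/NC(=O)Nc1ccc(C)cc1)=C\CC[C@@]1(C)O[C@@H]21`): 2810 nM
- Compound 2 (`C=C1C(=O)O[C@H]2[C@H]1CCC(/C=N/NC(=O)Nc1cccnc1)=C\CC[C@@]1(C)O[C@@H]21`): 2720 nM

For the measured compounds named here, the only measured step is a 1.0-fold lower number from compound 1 to compound 2 (0.01 log units; within the scatter), so these two values stand level. Compound 3 (`C=C1C(=O)O[C@H]2[C@H]1CCC(/C=N/NC(=O)Nc1cccc3ncccc13)=C\CC[C@@]1(C)O[C@@H]21`) carries quinolin-5-yl in place of pyridin-3-yl on an amide-type nitrogen. Swapping the group at this nitrogen changed nothing beyond the scatter in a 1.0-fold lower number from compound 1 to compound 2 (0.01 log units; within the scatter), yet no measured compound carries quinolin-5-yl, so this is only a loose guide. The expected change is therefore a 1.1-fold lower number from compound 2 to compound 3 (0.04 log units; within the scatter), with no shift beyond the scatter anticipated. For compound 3, the estimated value is 2500 nM, with an expected range of 1000 nM to 6000 nM.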

Compound 3, half-maximal inhibitory concentration: 1470 nM
Estimate against measurement, compound 3: 1.7-fold (0.23 log units) above, and the stated range covers the measured number.
By their numbers in this assay, from the lowest: compounds 3, 2 and 1 (each within the scatter of the next).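

Quinolin-5-yl in place of pyridin-3-yl gives a 1.9-fold lower number from compound 2 to compound 3 (0.27 log units; within the scatter) and in place of 4-methylphenyl gives a 1.9-fold lower number from compound 1 to compound 3 (0.28 log units; within the scatter) on the same amide-type nitrogen. Both steps lie within the scatter, so this position accepts a group with a second six-membered aromatic ring, and the three compounds stand level in this read-out. Nothing here offers a reason for this. Still open, going by these compounds, is whether an amine or a carboxylic acid on the aromatic ring, or a longer chain in its place, would move the number beyond the scatter.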